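The source may hold more compounds than are shown below. What is called first, only, known or untested is meant among the compounds shown, and "the series" means these compounds.

Three amides that share the indazole-bearing core have been tested in an assay on cells for inhibition of Amine oxidase [flavin-containing] B (Homo sapiens); a higher number here means a weaker inhibitor, a lower number a stronger inhibitor. Compound 1 `O=C(Nc1ccc2[nH]ncc2c1)c1ccc(Cl)c(Cl)c1` gives 12.4 nM. Compound 2 `O=C(Nc1ccc(F)c(Cl)c1)c1ccc2cn[nH]c2c1` gives 234 nM, and compound 3 `O=C(Nc1ccc(F)c(F)c1)c1ccc2cn[nH]c2c1` gives 1300 nM. Among these three numbers, compound 2 stands second highest: its nearest neighbour is compound 3, its furthest is compound 1, and both gaps lie beyond the scatter. For the measured compounds named here, the one single-point step available is a 5.6-fold higher number from compound 2 to compound 3 (0.74 log units; beyond the scatter).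

Compound 4 `O=C(Nc1ccc(O)c(Cl)c1)c1ccc2cn[nH]c2c1` differs from compound 2 by hydroxy in place of fluoro on an aromatic carbon. Going by the values given here, no measured step swaps a halogen for a hydroxy group, so the only guide is indirect: the step from compound 2 to compound 3 shows that a small exchange at this position of compound 2 already moves this assay beyond the scatter, and the hydroxy group departs further from a halogen than fluoro does. For compound 4 a weakening of a 3.0-fold higher number from compound 2 to compound 4 (0.48 log units; beyond the scatter) is therefore expected. Compound 4 is estimated at 700 nM, within 150 nM to 3500 nM.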

Compound 4, half-maximal inhibitory concentration: < 10000 nM
Compound 4: no number, only a limit; the forecaster's own chance of this, stated with the estimate: 5%; the middle value lies beyond the limit too.
By their numbers in this assay, from the lowest: compound 1; then compound 2; then compound 3.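

In this assay compound 4 gives only a limit of < 10000 nM and no number, so the step between compound 2 and compound 4 cannot be read. The compounds shown leave open how far, and in which direction, hydroxy in place of fluoro on an aromatic carbon moves the number.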